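Nitro in Place of Benzyloxy: Expecting the Next Number

The source may hold more compounds than are shown below. What is called first, only, known or untested is meant among the compounds shown, and "the series" means these compounds.

Compound 1 `O=C(/C=C/c1ccc2c(c1)B(O)OC2)c1ccc(-c2ccccc2)cc1` in a functional assay on SK-OV-3 cells (Homo sapiens) for cytotoxicity, read by MTT assay, with a stated time of 48 h; a higher number here means a weaker inhibitor, a lower number a stronger inhibitor: 4900 nM
Compound 2 `O=C(/C=C/c1ccc2c(c1)B(O)OC2)c1ccc(Br)cc1`: 4500 nM
Compound 3 `O=C(/C=C/c1ccc2c(c1)B(O)OC2)c1ccc(OCc2ccccc2)cc1`: 6000 nM

Compound 3 sits alongside the other two, the steps being a 1.2-fold higher number from compound 1 to compound 3 (0.09 log units; within the scatter) and a 1.3-fold higher number from compound 2 to compound 3 (0.12 log units; within the scatter). Compound 4 `O=C(/C=C/c1ccc2c(c1)B(O)OC2)c1ccc([N+](=O)[O-])cc1` differs from compound 3 in one place: nitro in place of benzyloxy on an aromatic carbon. All three measured steps exchange a group at that same aromatic carbon, and each stayed within the scatter, including a 1.1-fold lower number from compound 1 to compound 2 (0.04 log units; within the scatter). None of them involves nitro, so the bearing is indirect. On that basis no step beyond the scatter is expected in this assay for compound 4, in either direction. The estimate for compound 4 is 5000 nM, with a range of 2500 nM to 10000 nM, which is expected to mean a 1.2-fold lower number from compound 3 to compound 4 (0.08 log units; within the scatter).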

Compound 4, half-maximal inhibitory concentration: 7900 nM
Compound 4: middle estimate off by 1.6-fold (0.20 log units), on the low side, and the stated range covers the measured number.
By their numbers in this assay, from the lowest: compounds 2, 1, 3 and 4 (each within the scatter of the next).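

In this assay, nitro on this aromatic carbon joins the other groups without a clear shift: its exchange for benzyloxy (a 1.3-fold higher number from compound 3 to compound 4 (0.12 log units; within the scatter)) and for phenyl (a 1.6-fold higher number from compound 1 to compound 4 (0.21 log units; within the scatter)) stays within the scatter. So does its exchange for bromo (a 1.8-fold higher number from compound 2 to compound 4 (0.24 log units; within the scatter)), the largest step yet seen at this place. Nothing shown offers an explanation for this flat result. The compounds leave open whether an amine or a carboxylic acid on this carbon would produce a step beyond the scatter, and whether changes elsewhere on the shared core would do so.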